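From 4-bromophenyl to 3,4-dichlorophenyl on a weak inhibitor

The source may hold more compounds than are shown below. What is called first, only, known or untested is meant among the compounds shown, and "the series" means these compounds.

In a functional assay on HeLa cells (Homo sapiens) for antiproliferative activity, read by MTT assay (a higher number here means a weaker inhibitor, a lower number a stronger inhibitor), compound 1 (`COc1ccc(-c2ccnc(Nc3ccc([N+](=O)[O-])cc3)n2)cc1`) gives 980 nM, while compound 2 (`O=[N+]([O-])c1ccc(Nc2nccc(-c3ccc(Br)cc3)n2)cc1`) gives 25700 nM, the higher of the two numbers and so the weaker inhibitor. Compound 3 (`O=[N+]([O-])c1ccc(Nc2nccc(-c3ccc(Cl)c(Cl)c3)n2)cc1`) has not yet been measured, and it differs from compound 2 as follows: 3,4-dichlorophenyl in place of 4-bromophenyl on an aromatic carbon. Among the compounds with values here, the only measured step, a 26-fold higher number from compound 1 to compound 2 (1.42 log units; beyond the scatter), is large, but it put bromo in place of methoxy, a different swap from this one. It offers no direction here, so no shift beyond the scatter is expected in this assay. The estimated change is a 1.3-fold lower number from compound 2 to compound 3 (0.11 log units; within the scatter). Compound 3 is estimated at 20000 nM, with an expected range of 5000 nM to 60000 nM.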

Compound 3, half-maximal inhibitory concentration: 1840 nM
Compound 3: the middle estimate sits 11-fold (1.04 log units) above what was measured, outside the stated range (below it).
By their numbers in this assay, from the lowest: compounds 1 and 3 (each within the scatter of the next); then compound 2.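

In this assay, 3,4-dichlorophenyl in place of 4-bromophenyl is far from a neutral swap of halogens at this place on the shared core, giving a 14-fold lower number from compound 2 to compound 3 (1.15 log units; beyond the scatter). Halogen on this ring does not by itself mean a weak inhibitor: 3,4-dichlorophenyl and 4-methoxyphenyl stand together, with a 1.9-fold higher number from compound 1 to compound 3 (0.27 log units; within the scatter). No measurement here accounts for the gap between the two halogen-bearing rings.

Going by these compounds, whether the change from bromine to chlorine or the added chlorine carries the step stays open, and a 4-chlorophenyl group would separate the two. On these data alone, how an aminophenyl or a carboxyphenyl group would behave here is also open.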